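The compounds below may be only part of what the source reports. "The series", "measured", "known", "first", "only" and "open" are said of these compounds alone.

Compound 1, `Cc1nnc(SCc2ccccc2)n1N1C(=O)c2ccccc2C1=O`: in a functional assay on PC-3M cells (Homo sapiens) for cytotoxicity, read by MTT assay, with a stated time of 48 h (on this read-out lower numbers stand for stronger inhibition and higher numbers for weaker inhibition), compound 1 gives > 200000 nM, a limit of the assay.
Compound 2, `Cc1nnc(SCC(=O)c2ccccc2)n1N1C(=O)c2ccccc2C1=O`: in this assay compound 2 gives > 200000 nM, again only a limit.
Compound 3, `C#CCSc1nnc(C)n1N1C(=O)c2ccccc2C1=O`: in this assay compound 3 gives > 200000 nM, likewise a limit and not a number.

Compound 3 therefore stands at the limit of > 200000 nM in this assay, at which 3 of the 3 values shown sit; among the three measured compounds no order can be read. The unmeasured compound 4, `C#CCSc1nnc(CC)n1N1C(=O)c2ccccc2C1=O`, differs from compound 3 by methyl in place of hydrogen on a saturated chain carbon bound to an aromatic carbon. The measured steps all change the group on the saturated chain carbon bound to a sulfur, and each of them is unreadable: a step that the two limits leave unreadable from compound 1 to compound 2, a step that the two limits leave unreadable from compound 1 to compound 3 and a step that the two limits leave unreadable from compound 2 to compound 3. None of them touches the place altered in compound 4, and none gives a readable size, so no step beyond the scatter can be expected in this assay in either direction. Compound 4 is expected to sit where compound 3 sits, with an expected step that the limit leaves unreadable from compound 3 to compound 4. For compound 4 the estimate in this assay is 300000 nM, with a range from 100000 nM to 1000000 nM, most likely reported again only as a limit.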

Compound 4, half-maximal inhibitory concentration: > 200000 nM
Compound 4: a limit, no number; the forecaster's own chance of this, stated with the estimate: 85%; the middle value does not contradict the limit.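

No new step can be read: compound 3 and compound 4 each give only a limit in this assay, so the change from hydrogen to methyl has no readable size. The compounds shown leave open how any of them would compare with the others on a measured number.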